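The compounds below may be only part of what the source reports. "The series", "measured", "known", "first", "only" and "open" are said of these compounds alone.

Measured in a functional assay on MDA-MB-231 cells (Homo sapiens) for antiproliferative activity, read by MTT assay, with a stated time of 72 h; a lower number here means a stronger inhibitor, a higher number a weaker inhibitor:
- compound 1 `O=C(CCc1cccc2c1B(O)OC2)Nc1nccs1`: > 100000 nM
- compound 2 `CC(C)(C)OC(=O)Nc1ccc(NC(=O)CCc2cccc3c2B(O)OC3)cc1`: 29000 nM
- compound 3 `CC(C)(C)OC(=O)NCc1ccc(NC(=O)CCc2cccc3c2B(O)OC3)cc1`: 1300 nM

Compound 1 stands at > 100000 nM, which is a limit of the assay and not a number. This is the limit of > 100000 nM in this assay, at which 1 of the 3 values shown sits.

The next compound is compound 4 `O=C(CCc1cccc2c1B(O)OC2)Nc1cccc(I)c1`, with 3-iodophenyl in place of 1,3-thiazol-2-yl on an amide-type nitrogen.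

Among the measured compounds shown here, no measured step makes this change. For the measured compounds named here, the only measured step is a 22-fold lower number from compound 2 to compound 3 (1.35 log units; beyond the scatter). It is large, but it falls on an aromatic carbon and not on the amide-type nitrogen, so its size does not carry over directly. It does show that this assay responds strongly to what the six-membered aromatic ring carries.

A lower number than that of compound 1 is expected for compound 4 because compound 2 gives 29000 nM, and it too has a six-membered aromatic ring of carbon only on the amide-type nitrogen. The size of the step stays loose, since its starting point is a limit. The expected move is an at least 5.0-fold lower number from compound 1 to compound 4 (0.69 log units; beyond the scatter). For compound 4 the estimate is 20000 nM, with an expected range of 4000 nM to 100000 nM.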

Compound 4, half-maximal inhibitory concentration: 5300 nM
Compound 4: the middle estimate sits 3.8-fold (0.58 log units) above what was measured, and the stated range covers the measured number.
By their numbers in this assay, from the lowest: compound 3; then compound 4; then compound 2. At a limit, above all of these: compound 1.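

In this assay the substituent on the amide-type nitrogen proves able to move the read-out: 3-iodophenyl in place of 1,3-thiazol-2-yl gives an at least 18-fold lower number from compound 1 to compound 4 (1.27 log units; beyond the scatter) and this is the only step shown at this position, the earlier one having fallen on an aromatic carbon. Compound 1 gives > 100000 nM and this is a limit of the assay and not a number. On these data alone, the full size of the step therefore stays unknown because its starting point is a limit: the limit of > 100000 nM in this assay, at which 1 of the 4 values shown sits.

As far as these compounds go, the step replaces a five-membered aromatic ring with 2 hetero atoms by a six-membered aromatic ring of carbon only and brings in iodine at the same time, so it remains open whether the ring or the iodine carries the change, a question that a plain phenyl on the amide-type nitrogen would separate. Also open, from the compounds shown here alone, is whether an aminomethyl group or a carboxylic acid in place of the iodine on that ring would keep the lower number.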